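Replacing an amine chain with a furan ester: cytotoxicity outlook

A few compounds are considered here, and "the series" means these few. Any claim that something is new, unique, unknown or untested is made for them only; others in the source may bear on it.

Compound 1, `COc1ccc(/C=C/C(=O)c2ccc(OC)c3c2OC(C)(C)C=C3)cc1OCCCN(C)C`, gives 5550 nM in a functional assay on HepG2 cells (Homo sapiens) for cytotoxicity, read by MTT assay; on this read-out higher numbers stand for weaker inhibition and lower numbers for stronger inhibition. Compound 2, `C=CC(=O)Oc1cc(/C=C/C(=O)c2ccc(OC)c3c2OC(C)(C)C=C3)ccc1OC`, gives 160 nM in this assay. Compound 3, `COc1ccc(/C=C/C(=O)c2ccc(OC)c3c2OC(C)(C)C=C3)cc1OC(=O)CCl`, gives 120 nM in this assay.

Among these three, compound 1 stands with the highest number, meaning the weakest inhibition. Compound 4, `COc1ccc(/C=C/C(=O)c2ccc(OC)c3c2OC(C)(C)C=C3)cc1OC(=O)c1ccco1`, differs from compound 1 in one place: (furan-2-yl)carbonyl in place of 3-(dimethylamino)propyl on an oxygen on an aromatic ring. The two measured steps that bear on this both exchange the 3-(dimethylamino)propyl on that same oxygen for a carbonyl-bearing group: a 35-fold lower number from compound 1 to compound 2 (1.54 log units; beyond the scatter) and a 46-fold lower number from compound 1 to compound 3 (1.67 log units; beyond the scatter). Between those two carbonyl groups the difference was small, a 1.3-fold lower number from compound 2 to compound 3 (0.12 log units; within the scatter). A (furan-2-yl)carbonyl is a third carbonyl-bearing group on that oxygen, so a large step downward in this assay is expected, though the two examples so far do not show whether every such group gives the same size of step. Compound 4 is therefore estimated at 600 nM, within a range of 150 nM to 2500 nM, an expected 9.3-fold lower number from compound 1 to compound 4 (0.97 log units; beyond the scatter).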

Compound 4, half-maximal inhibitory concentration: 370 nM
Beside the measured number, compound 4's estimate is 1.6-fold (0.21 log units) above it; the measured number falls inside the stated range.
By their numbers in this assay, from the lowest: compounds 3 and 2 (each within the scatter of the next); then compound 4; then compound 1.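

In this assay, a third carbonyl-bearing group on the oxygen on the aromatic ring also gives a large drop, with a 15-fold lower number from compound 1 to compound 4 (1.18 log units; beyond the scatter) when (furan-2-yl)carbonyl enters, so all three such groups shown lie well under the amine chain. The new finding is that the group on the carbonyl carbon can change the number: vinyl and chloromethyl lay within the scatter of each other, but furan-2-yl gives a 3.1-fold higher number from compound 3 to compound 4 (0.49 log units; beyond the scatter) and a 2.3-fold higher number from compound 2 to compound 4 (0.36 log units; beyond the scatter) in modest steps beyond the scatter. A carbonyl on this oxygen therefore does not fix the size of the drop by itself.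

No measurement here offers an explanation for these differences. A plain propyl group on that oxygen, with no amine, would help show whether the high number of compound 1 goes with the dimethylamino nitrogen or with the chain.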